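The source may report more compounds than this note shows. Statements on the series, on what has been measured and on what is new or still open speak of the compounds shown alone.

Of the compounds shown here, three sharing one core have been measured in an assay on HepG2 cells for agonist activity at nuclear receptor subfamily 1 group I member 3 (Homo sapiens), read by a luciferase reporter, with a stated time of 23 h; on this read-out higher numbers stand for an effect only at larger amounts of compound and lower numbers for an effect already at smaller amounts. Compound 1 `CCc1nc2sccn2c1/C=N/OCc1ccc(Cl)c(Cl)c1` gives 2600 nM. Compound 2 `Clc1ccc(CO/N=C/c2c(-c3cccc4ccccc34)nc3sccn23)cc1Cl` gives 940 nM, and compound 3 `Clc1ccc(CO/N=C/c2c(-c3ccc(Br)cc3)nc3sccn23)cc1Cl` gives 480 nM; on these numbers compound 3 stands lowest of the three, though its number and that of compound 2 lie within the scatter of each other. The steps run a 2.8-fold lower number from compound 1 to compound 2 (0.44 log units; beyond the scatter) and a 5.4-fold lower number from compound 1 to compound 3 (0.73 log units; beyond the scatter), while the step of a 2.0-fold lower number from compound 2 to compound 3 (0.29 log units; within the scatter) is within the scatter.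

Compound 4 `Clc1ccc(CO/N=C/c2c(-c3ccc(C4CCCCC4)cc3)nc3sccn23)cc1Cl` differs from compound 3 by cyclohexyl in place of bromo on an aromatic carbon. The step that bears most directly on it is the exchange of one aryl group for another, from compound 2 to compound 3, which stayed within the scatter; the two steps from compound 1 show that replacing ethyl by an aryl group lowered the number modestly. Nothing measured here changes a substituent on the pendant aryl ring itself. The author therefore expects for compound 4 a step of a 1.2-fold lower number from compound 3 to compound 4 (0.08 log units; within the scatter) in this assay, likely within the scatter, and estimates 400 nM with a range from 150 nM to 1200 nM.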

Compound 4, half-maximal effective concentration: > 100000 nM
Compound 4 was reported as a limit; the forecaster's own chance of this, stated with the estimate: 5%; middle value at least 250-fold (2.39 log units) away from the limit.
By their numbers in this assay, from the lowest: compounds 3 and 2 (each within the scatter of the next); then compound 1. At a limit, above all of these: compound 4.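

Compound 4 is reported only as a limit, not as a number: the limit of > 100000 nM in this assay, at which 1 of the 4 values shown sits.

Read against that limit, the exchange of bromo for cyclohexyl gives an at least 200-fold higher number from compound 3 to compound 4 (2.31 log units; beyond the scatter), a large step where all earlier steps were modest or within the scatter. It is also the first change shown on the pendant aryl ring, on the aromatic carbon para to a large group, and it shows that this place does not accept every group: bromo there leaves a measurable number, whereas cyclohexyl does not.

With only these two groups shown at this place, the compounds leave open how the number changes between them, and what the data cannot tell is why the step is so large. A methyl, a phenyl, an amine or a carboxylic acid at this place could each fall anywhere along that range.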